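A few compounds are considered here, and "the series" means these few. Any claim that something is new, unique, unknown or untested is made for them only; others in the source may bear on it.

In a functional assay on HeLa cells (Homo sapiens) for inhibition, with a stated time of 72 h (on this read-out lower numbers stand for an effect already at smaller amounts and higher numbers for an effect only at larger amounts of compound), three compounds have been measured so far:

Compound 1 `COc1cc(OCc2cnc(Cl)c(Cl)c2)ccc1CNCc1ccncc1`: 400 nM
Compound 2 `COc1cc(CNCc2ccncc2)ccc1OCc1ccc(F)cc1`: 6400 nM
Compound 3 `COc1cc(CNCCSc2nnnn2C)ccc1OCc1ccc(Cl)nc1`: 86000 nM

Compound 3, at 86000 nM, carries the highest number of the three. The gaps to compound 2, at 6400 nM, and to compound 1, at 400 nM, both lie beyond the usual scatter. No two of these compounds differ in only one place, so the measurements do not isolate the effect of any single structural change.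

Compound 4 `COCCNCc1ccc(OCc2ccc(Cl)nc2)c(OC)c1` has not yet been measured. It differs from compound 3 in one place: methoxy in place of (1-methyl-1H-tetrazol-5-yl)sulfanyl on a saturated chain carbon, two bonds along the chain from an amine nitrogen. Methoxy stands in place of (1-methyl-1H-tetrazol-5-yl)sulfanyl on a saturated chain carbon, two bonds along the chain from an amine nitrogen, so the 2-((1-methyl-1H-tetrazol-5-yl)sulfanyl)ethyl group becomes 2-methoxyethyl.

Among the compounds with values here, no measured step speaks directly to this change, so the expectation rests only on the spread of values. With compound 3 at the top of that spread at 86000 nM, a moderate move towards a lower number is expected, although a result within the scatter remains possible. The expected step is a 4.3-fold lower number from compound 3 to compound 4 (0.63 log units; beyond the scatter). For compound 4 the estimated value is 20000 nM, with an expected range from 4000 nM to 80000 nM.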

Compound 4, half-maximal effective concentration: 97000 nM
Compound 4: middle estimate off by 4.9-fold (0.69 log units), on the low side, and the stated range ends below it.
By their numbers in this assay, from the lowest: compound 1; then compound 2; then compounds 3 and 4 (each within the scatter of the next).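

In this assay, within the data shown here, methoxy in place of (1-methyl-1H-tetrazol-5-yl)sulfanyl on a saturated chain carbon, two bonds along the chain from an amine nitrogen gives a 1.1-fold higher number from compound 3 to compound 4 (0.05 log units; within the scatter) and thus provides the first comparison in this set that isolates a single change. At this position, therefore, a group of 7 heavy atoms with one five-membered aromatic ring and 5 hydrogen-bond acceptors and a group of 2 heavy atoms with no ring and 1 hydrogen-bond acceptor give values within the scatter of each other, so this exchange does not separate the two compounds on this read-out. No accompanying data explain this result.

Going by these compounds, whether any group at this chain position can move the number beyond the scatter remains open, for example a terminal primary amine, a carboxylic acid or a longer chain such as 3-methoxypropyl. Also open is which structural differences account for the values of compound 1 and compound 2, since neither differs in only one place from any other compound shown.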